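The source may report more compounds than this note shows. Statements on the series, on what has been measured and on what is new or still open speak of the compounds shown alone.

Measured compounds:
compound 1, `COC(=O)CCn1cc(C(=O)C(=O)Nc2ccc(OC)nc2)c2ccccc21`, 168 nM;
compound 2, `COc1ccc(NC(=O)C(=O)c2cn(C(C)C)c3cccnc23)cn1`, a limit.

For the measured compounds named here, in a functional assay on FaDu cells (Homo sapiens) for cytotoxicity, read by MTT assay, with a stated time of 72 h (on this read-out lower numbers stand for higher toxicity in this test and higher numbers for lower toxicity in this test), compound 1 gives 168 nM, the only real number among the two values shown. Compound 2 reaches only the limit of the test in this assay, > 10000 nM, so its value is a limit and not a number; it is described by the limit of > 10000 nM in this assay, at which 1 of the 2 values shown sits. Compound 3, `COc1ccc(NC(=O)C(=O)c2cn(C3CCCC3)c3ccccc23)cn1`, has not yet been measured in this assay. It differs from compound 1 in one place: cyclopentyl in place of 2-(methoxycarbonyl)ethyl on an aromatic nitrogen. No step between two measured compounds speaks to this change, so there is no shown step in this assay on which to rest an expectation. Compound 3 is therefore expected to stay close to compound 1, with a step from compound 1 to compound 3 of about a 1.4-fold lower number from compound 1 to compound 3 (0.15 log units; within the scatter), not beyond the usual scatter. In this assay compound 3 is estimated at 120 nM, within a range from 20 nM to 1500 nM.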

Compound 3, concentration lethal to 50% of the cells: 370 nM
Compound 3: the middle estimate sits 3.1-fold (0.49 log units) below what was measured, and the stated range covers the measured number.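

For the compounds shown here, exchanging 2-(methoxycarbonyl)ethyl for cyclopentyl on the aromatic nitrogen gives, in this assay, a 2.2-fold higher number from compound 1 to compound 3 (0.34 log units; beyond the scatter), the first step that can be read at this position. The position therefore responds to what it carries, yet only modestly: compound 3 still gives a real number, although a ring of carbon only, with no hydrogen-bond acceptors, has replaced an open chain that carries them. Nothing measured among the compounds shown accounts for the size or direction of this step.

A single exchange cannot separate the loss of the methoxycarbonyl group from the arrival of the ring. The compounds shown leave open how a carboxylic acid or an amine at the end of the chain, a longer chain, or a six-membered carbon ring on the same nitrogen would compare.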